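Removing the Nitro Group from Compound 3

The source may hold more compounds than are shown below. What is called first, only, known or untested is meant among the compounds shown, and "the series" means these compounds.

Compound 3 `N#Cc1c(Nc2cccc([N+](=O)[O-])c2)nc(SCc2cn(Cc3ccccc3Cl)nn2)nc1-c1ccccc1` gives 43100 nM in a functional assay on MGC-803 cells (Homo sapiens) for inhibition, read by MTT assay, with a stated time of 72 h (on this read-out lower numbers stand for stronger inhibition and higher numbers for weaker inhibition), the highest number among the three measured compounds. Compound 1 `N#Cc1c(Nc2ccc(Cl)cc2)nc(SCc2cn(Cc3ccccc3Cl)nn2)nc1-c1ccccc1` gives 5850 nM, and compound 2 `COc1ccccc1Nc1nc(SCc2cn(Cc3ccccc3Cl)nn2)nc(-c2ccccc2)c1C#N` gives 5800 nM. Compound 4 `N#Cc1c(Nc2ccccc2)nc(SCc2cn(Cc3ccccc3Cl)nn2)nc1-c1ccccc1` has not been measured; it differs from compound 3 by hydrogen in place of nitro on an aromatic carbon. Within the data shown here, two measured steps bear on this change, since both alter the same aryl group on the nitrogen: a 7.4-fold higher number from compound 1 to compound 3 (0.87 log units; beyond the scatter) and a 7.4-fold higher number from compound 2 to compound 3 (0.87 log units; beyond the scatter). Both show the 3-nitrophenyl variant standing well above the others, while 4-chlorophenyl and 2-methoxyphenyl give numbers within the scatter of each other. Removing the nitro is expected to bring the number back down, roughly a 5.4-fold lower number from compound 3 to compound 4 (0.73 log units; beyond the scatter). Compound 4 is estimated at 8000 nM, with a range from 3000 nM to 25000 nM.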

Compound 4, half-maximal inhibitory concentration: > 64000 nM
Compound 4: only a limit was reported (the forecaster's own chance of this, stated with the estimate: 5%); middle value at least 8.0-fold (0.90 log units) from the limit.
By their numbers in this assay, from the lowest: compounds 2 and 1 (each within the scatter of the next); then compound 3. At a limit, above all of these: compound 4.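

In this assay, compound 4 has only a limit, not a number: the limit of > 64000 nM in this assay, at which 1 of the 4 values shown sits. Taking off the nitro group brings no return towards compounds 1 and 2, and the floor of this step does not separate the two compounds: an at least 1.4-fold higher number from compound 3 to compound 4 (0.17 log units; that floor lies within the scatter). Hydrogen in place of the ring groups of the other two gives much larger steps, an at least 10-fold higher number from compound 1 to compound 4 (1.03 log units; beyond the scatter) and an at least 11-fold higher number from compound 2 to compound 4 (1.04 log units; beyond the scatter), so among these compounds the lower numbers go with chloro and methoxy, not with a bare phenyl.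

The limit leaves the true size of the step to compound 4 unknown. As far as these compounds go, whether a methyl, fluoro or amino group on this ring would also bring the number down remains open.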